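Phenyl in Place of Methyl on a Selenium Heterocycle

The compounds below may be only part of what the source reports. "The series", "measured", "known", "first", "only" and "open" are said of these compounds alone.

Compound 1, `Cc1c[se]c(N/N=C/c2ccc(Cl)cc2)n1`, in a functional assay on HepG2 cells (Homo sapiens) for cytotoxicity, read by XTT assay, with a stated time of 72 h; on this read-out higher numbers stand for weaker inhibition and lower numbers for stronger inhibition: 56500 nM
Compound 2, `Clc1ccc(/C=N/Nc2nc(-c3ccccc3)c[se]2)cc1`, in this assay: 42500 nM
Compound 3, `Cc1c[se]c(NNC(=O)c2ccc(Cl)cc2)n1`, in this assay: > 79400 nM, a limit of the assay rather than a number.

Compound 1 and compound 2 differ in one place: phenyl in place of methyl on an aromatic carbon. In this assay that change gave a 1.3-fold lower number from compound 1 to compound 2 (0.12 log units; within the scatter). Compound 3 sits on a different core; the difference between the core of compound 1 and the core of compound 3 is not broken down here. The value of compound 3 is a limit, as the limit of > 79400 nM in this assay, at which 1 of the 3 values shown sits, records.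

Compound 4, `O=C(NNc1nc(-c2ccccc2)c[se]1)c1ccc(Cl)cc1`, has not been measured. It relates to compound 3 by the same change seen between compound 1 and compound 2: phenyl in place of methyl on an aromatic carbon. The surroundings of the place are the same word for word, so it is the same change. Compound 4 is expected to move by about a step that the limit leaves unreadable from compound 3 to compound 4 in this assay, an expectation that rests on a 1.3-fold lower number from compound 1 to compound 2 (0.12 log units; within the scatter). Compound 4 is therefore estimated at 80000 nM, within a range from 40000 nM to 200000 nM, with a real chance that the assay again reports only a limit.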

Compound 4, half-maximal inhibitory concentration: 62900 nM
Compound 4: middle estimate off by 1.3-fold (0.10 log units), on the high side, and the stated range covers the measured number.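

In this assay phenyl in place of methyl on an aromatic carbon of the second core gave an at least 1.2-fold lower number from compound 3 to compound 4 (0.10 log units; that floor lies within the scatter) and so nothing here shows the change producing a step beyond the scatter on either core, though the true step on this core may be larger. Compound 3 has only > 79400 nM as its value, which is a limit of the assay and not a number. The two steps can be set side by side, but they cannot be shown to match or to differ: the same change on two cores in this assay, a 1.3-fold lower number (0.12 log units; within the scatter) from compound 1 to compound 2 and an at least 1.2-fold lower number (0.10 log units; that floor lies within the scatter) from compound 3 to compound 4; the limit leaves it open whether they differ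

The compounds shown leave open how other groups would read at this place, such as an amine, a carboxylic acid or a longer chain in place of methyl or phenyl. They also leave open whether the change would read the same way on cores other than these two.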